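Replacing the Sulfamoyl Group with a Methyltetrazole

The compounds below may be only part of what the source reports. "The series", "measured", "known", "first", "only" and "open" are said of these compounds alone.

Compound 1, `CC(C)(N)CC(=O)N[C@@H]1CCc2ccccc2N(Cc2ccc(-c3ccccc3-c3nnn(CC(=O)O)n3)cc2)C1=O`: 0.2 uM
Compound 2, `CC(C)(N)CC(=O)N[C@@H]1CCc2ccccc2N(Cc2ccc(-c3ccccc3S(=O)(=O)NC(C)(C)C)cc2)C1=O`: 4 uM
Compound 3, `CC(C)(N)CC(=O)N[C@@H]1CCc2ccccc2N(Cc2ccc(-c3ccccc3S(N)(=O)=O)cc2)C1=O`: 3 uM

In a functional assay (Pituitary gland cell) with Rattus norvegicus as the target (a higher number here means that more compound is needed for the effect, a lower number that less compound is needed), compound 3 gives 3 uM, the second highest of the three numbers. Its nearest neighbour is compound 2, where a 1.3-fold lower number from compound 2 to compound 3 (0.12 log units; within the scatter). Its furthest is compound 1, where a 15-fold higher number from compound 1 to compound 3 (1.18 log units; beyond the scatter).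

Compound 4, `Cn1nnc(-c2ccccc2-c2ccc(CN3C(=O)[C@H](NC(=O)CC(C)(C)N)CCc4ccccc43)cc2)n1`, differs from compound 3 by 2-methyl-2H-tetrazol-5-yl in place of sulfamoyl on an aromatic carbon. The step that bears on this change is the one in the opposite direction, a 15-fold higher number from compound 1 to compound 3 (1.18 log units; beyond the scatter), in which a tetrazole carrying a carboxymethyl group gave way to sulfamoyl. The related step of a 20-fold higher number from compound 1 to compound 2 (1.30 log units; beyond the scatter) points the same way with a different sulfonamide. Going back from sulfamoyl to a tetrazole should therefore lower the number, but no measured pair compares a methyl with a carboxymethyl on the tetrazole, and compound 1 gives 0.2 uM only with the carboxymethyl. The estimate for compound 4 accordingly sits between the two measured extremes. Compound 4 is expected to show a step of a 5.0-fold lower number from compound 3 to compound 4 (0.70 log units; beyond the scatter) in this assay. Compound 4 is thus estimated at 0.6 uM, with a range from 0.15 uM to 2.5 uM.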

Compound 4, concentration for half-maximal effect: 0.3 uM
The estimate for compound 4 lay 2.0-fold (0.30 log units) above the measured number; the measured number falls inside the stated range.
By their numbers in this assay, from the lowest: compounds 1 and 4 (each within the scatter of the next); then compounds 3 and 2 (each within the scatter of the next).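

Putting 2-methyl-2H-tetrazol-5-yl in place of sulfamoyl on this aromatic carbon brings a 10-fold lower number from compound 3 to compound 4 (1.00 log units; beyond the scatter) in this assay and putting it in place of (tert-butyl)sulfamoyl brings a 13-fold lower number from compound 2 to compound 4 (1.12 log units; beyond the scatter) so both sulfonamides now stand clearly apart from a tetrazole that carries no carboxy group. Among these compounds, until now the only tetrazole in the set was the one with the carboxymethyl group, so the ring and the carboxy on its chain could not be told apart. Replacing that carboxy with hydrogen gives a 1.5-fold higher number from compound 1 to compound 4 (0.18 log units; within the scatter) which shows that, among these compounds, the lower numbers at this position go with the tetrazole and do not require the carboxy group.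

Nothing measured here accounts for the gap between the tetrazoles and the sulfonamides. As far as these compounds go, how an unsubstituted tetrazole, a carboxylic acid set directly on this aromatic carbon, or a longer chain ending in an amine on the tetrazole would compare in this assay remains open.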